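Cyano in place of 4-nitrophenyl: compound 3 to compound 4

This account rests on a few compounds, and the source may have more. Where it says the series, first, only, none or still open, it means among the compounds named here.

In a functional assay on HeLa cells (Homo sapiens) for inhibition, read by MTT assay, with a stated time of 48 h (a higher number here means a weaker inhibitor, a lower number a stronger inhibitor), compound 3 (`CCOC(=O)C1=C(N/N=C(/Cl)c2ccc([N+](=O)[O-])cc2)Nc2[nH]nc(C)c2C1c1ccc(N(C)C)cc1`) gives 46200 nM. Compound 2 (`CCOC(=O)C1=C(N/N=C(\C#N)C(N)=O)Nc2[nH]nc(C)c2C1c1ccc(N(C)C)cc1`) gives 47300 nM and compound 1 (`CCOC(=O)C1=C(N/C=N/c2nnc(S(N)(=O)=O)s2)Nc2[nH]nc(C)c2C1c1ccc(N(C)C)cc1`) gives 26300 nM. All three lie within the scatter of one another, so compound 3 holds no distinct rank.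

Compound 4 (`CCOC(=O)C1=C(N/N=C(/Cl)C#N)Nc2[nH]nc(C)c2C1c1ccc(N(C)C)cc1`) carries cyano in place of 4-nitrophenyl on a carbon with a double bond to nitrogen.

The closest measured step is a 1.0-fold lower number from compound 2 to compound 3 (0.01 log units; within the scatter). Compound 2 likewise carries cyano on such a carbon and has no ring in that group. The other two steps, a 1.8-fold higher number from compound 1 to compound 2 (0.25 log units; within the scatter) and a 1.8-fold higher number from compound 1 to compound 3 (0.24 log units; within the scatter), also change this part of the molecule, and all three stay within the scatter. Three compounds are a thin basis, but no step beyond the scatter is expected in this assay.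

The expected change is a 1.2-fold lower number from compound 3 to compound 4 (0.06 log units; within the scatter). The estimate for compound 4 is 40000 nM, with an expected range of 18000 nM to 90000 nM.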

Compound 4, half-maximal inhibitory concentration: 26200 nM
Estimate against measurement, compound 4: 1.5-fold (0.18 log units) above, and the stated range covers the measured number.
By their numbers in this assay, from the lowest: compounds 4, 1, 3 and 2 (each within the scatter of the next).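

Replacing 4-nitrophenyl with cyano on a carbon with a double bond to nitrogen removes the only aromatic ring in this group, yet the step stays within the scatter in this assay (a 1.8-fold lower number from compound 3 to compound 4 (0.25 log units; within the scatter)). Chloro in place of carbamoyl on the same carbon is also within the scatter (a 1.8-fold lower number from compound 2 to compound 4 (0.26 log units; within the scatter)), as is the exchange of the whole substituent on the amine nitrogen for the ring-free group of compound 4 (a 1.0-fold lower number from compound 1 to compound 4 (0.00 log units; within the scatter)). No measurement here explains this flat response.

Going by these compounds, whether a carboxylic acid or an amine on this carbon would give a step beyond the scatter remains open. All four compounds share one core, so the effect of changes elsewhere, such as to the ethyl ester, is also unknown.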